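The compounds below may be only part of what the source reports. "The series", "measured", "known", "first", "only" and "open" are said of these compounds alone.

Working notes on the series. Compound 1 `CNCc1ccc2c(c1)nc(Cn1c(=O)n(C(C)C)c3ccccc31)n2CCC(C)C` is tested in an ADME assay on HEp-2 cells (Homo sapiens) for cytotoxicity (on this read-out higher numbers stand for lower toxicity in this test and lower numbers for higher toxicity in this test), where compound 1 gives 1480 nM. Compound 2 `CC(C)CCn1c(Cn2c(=O)n(C)c3ccccc32)nc2cc(-c3nnn(C)n3)ccc21` in this assay gives 2970 nM; the two numbers sit within the usual scatter of each other, so no order between compound 1 and compound 2 is claimed. Compound 3 `CC(C)CCn1c(Cn2c(=O)n(C(C)C)c3ccccc32)nc2cc(-c3nn[nH]n3)ccc21` is not yet measured. It differs from compound 1 as follows: 2H-tetrazol-5-yl in place of (methylamino)methyl on an aromatic carbon. Among the compounds with values here, no measured step covers this change; with compound 2 as the only other point, little shift is expected. For compound 3 in this assay the expected step from compound 1 is a 1.5-fold higher number from compound 1 to compound 3 (0.17 log units; within the scatter), giving an estimate of 2200 nM (range 800 nM to 6500 nM).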

Compound 3, half-maximal cytotoxic concentration: 2000 nM
Compound 3: the middle estimate sits 1.1-fold (0.04 log units) above what was measured, and the stated range covers the measured number.
By their numbers in this assay, from the lowest: compounds 1, 3 and 2 (each within the scatter of the next).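

On the aromatic carbon of the shared core, 2H-tetrazol-5-yl in place of (methylamino)methyl gives a 1.4-fold higher number from compound 1 to compound 3 (0.13 log units; within the scatter) in this assay, the first step read at this position. Replacing a group with no ring by a five-membered aromatic ring with 4 hetero atoms therefore leaves this read-out within the scatter. No evidence on a cause accompanies this result. Open, as far as these compounds go, is whether a carboxylic acid or a tertiary amine on this aromatic carbon would also stay within the scatter of compound 1.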